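From Methylfuran to Pyridine: Expecting the Next Measurement

The compounds below may be only part of what the source reports. "The series", "measured", "known", "first", "only" and "open" are said of these compounds alone.

Compound 1, `Cc1nc(-c2ccccc2NCC2=NCCN2)co1`, was tested in a functional assay for activation of Alpha-1B adrenergic receptor (Homo sapiens), read by calcium flux (a higher number here means that more compound is needed for the effect, a lower number that less compound is needed), where it gave only a limit of the assay, < 5020 nM. Compound 2, `Cc1ccc(-c2ccccc2NCC2=NCCN2)o1`, gives 46.8 nM in this assay. The step that the limit leaves unreadable from compound 1 to compound 2 cannot be sized because the limit of < 5020 nM in this assay, at which 1 of the 2 values shown sits, hides its true extent. Among the compounds with values here, compound 2 therefore holds the only real number in this assay, the other entry being a limit. Compound 3, `c1ccc(-c2ccccc2NCC2=NCCN2)nc1`, differs from compound 2 by pyridin-2-yl in place of 5-methylfuran-2-yl on an aromatic carbon. Within the data shown here, the single measured step touches this same aromatic carbon, yet its size is unreadable, so the data give no measured guide to the size or direction of the new step. Compound 3 is expected to give roughly 200 nM in this assay, within a range of 40 nM to 2000 nM. This estimate corresponds to an expected step of a 4.3-fold higher number from compound 2 to compound 3 (0.63 log units; beyond the scatter).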

Compound 3, half-maximal effective concentration: 30.2 nM
Compound 3: the middle estimate sits 6.6-fold (0.82 log units) above what was measured; the measured number lies below the stated range.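

In this assay, placing pyridin-2-yl in place of 5-methylfuran-2-yl on this aromatic carbon gives a 1.5-fold lower number from compound 2 to compound 3 (0.19 log units; within the scatter). Within the data shown here, this is the first step at this position whose size can be read, and it shows that a six-membered aromatic ring with a nitrogen and a five-membered aromatic ring with an oxygen can stand here without a difference beyond the scatter. The steps from compound 1 to the other two compounds cannot be read, since its entry is a limit of the assay: the limit of < 5020 nM in this assay, at which 1 of the 3 values shown sits.

The swap changes the ring and drops the methyl group together, so the compounds shown cannot separate those two changes. On these data alone, how a plain phenyl ring, an amine or a longer chain on this carbon would read in this assay remains open.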